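Chain homologation of the phenol nitrooxy ester

The compounds below may be only part of what the source reports. "The series", "measured", "known", "first", "only" and "open" are said of these compounds alone.

Notes on the series. Compound 1 `COc1cc(/C=C/C(=O)OCCCCCO[N+](=O)[O-])ccc1OCCCCCO[N+](=O)[O-]` carries a 5-(nitrooxy)pentyl chain on both the ester oxygen and the phenolic oxygen; in a functional assay on HeLa cells (Homo sapiens) for cytotoxicity, read by resazurin assay, with a stated time of 72 h (on this read-out higher numbers stand for weaker inhibition and lower numbers for stronger inhibition), compound 1 reaches only the limit of > 50000 nM, which is the limit of the assay rather than a number (the limit of > 50000 nM in this assay, at which 1 of the 3 values shown sits). Compound 2 `COc1cc(/C=C/C(=O)OCCCCCO[N+](=O)[O-])ccc1O`, with hydrogen in place of 5-(nitrooxy)pentyl on the aromatic oxygen, gives 13400 nM in this assay, so an at least 3.7-fold lower number from compound 1 to compound 2 (0.57 log units; beyond the scatter). Compound 3 `COc1cc(/C=C/C(=O)OCc2c(-c3ccccc3)no[n+]2[O-])ccc1O` gives 7820 nM in this assay. Among the two numbers shown, compound 2 stands highest, but compound 3 sits within the scatter of it, so no order between the two can be stated.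

Compound 4 `COc1cc(/C=C/C(=O)OCCCCCCO[N+](=O)[O-])ccc1O` differs from compound 2 in one place: (nitrooxy)methyl in place of nitrooxy on a saturated chain carbon, five bonds along the chain from an oxygen next to a carbonyl group. Within the data shown here, none of the measured steps lengthens or shortens the ester chain; the only step measured removes a whole chain from the aromatic oxygen, which is a different kind of change and gives no guide on direction here. Without such evidence no step beyond the scatter is expected in this assay for compound 4, and a 1.0-fold lower number from compound 2 to compound 4 (0.01 log units; within the scatter) is the expected outcome. Compound 4 is therefore estimated at 13000 nM, within 5000 nM to 35000 nM.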

Compound 4, half-maximal inhibitory concentration: 16300 nM
The estimate for compound 4 lay 1.3-fold (0.10 log units) below the measured number; the measured number falls inside the stated range.
By their numbers in this assay, from the lowest: compounds 3, 2 and 4 (each within the scatter of the next, the first and the last beyond it). At a limit, above all of these: compound 1.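

Among the compounds shown, a 1.2-fold higher number from compound 2 to compound 4 (0.09 log units; within the scatter) is the only step on the ester chain, whereas the earlier step was on the aromatic oxygen, and it is read in this assay as within the scatter, so compound 2 and compound 4 cannot be ordered. At this position, five bonds along the chain from an oxygen next to a carbonyl group, (nitrooxy)methyl in place of nitrooxy therefore leaves the number indistinguishable from that of compound 2, and the phenol nitrooxy ester stays in the same range on this one added carbon. No measurement at hand bears on why the step is this small.

On these data alone, one step cannot define a trend in chain length, so it remains open whether a shorter chain such as 3-(nitrooxy)propyl, or a chain longer than that of compound 4, would give a step beyond the scatter. Also open, as far as these compounds go, is whether a carboxylic acid or an amine in place of nitrooxy on the same chain would give a number distinct from that of compound 2, and thus whether the nitrooxy group matters at all here.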